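A few compounds are considered here, and "the series" means these few. Any claim that something is new, unique, unknown or untested is made for them only; others in the source may bear on it.

Compound 1 `CNCCn1c(=O)ccc2c(C)cc(C)nc21` gives 21.1 ug/mL in an assay on isolated protein (strain Charles River) for antagonist activity at histamine H2 receptor (Rattus norvegicus); on this read-out lower numbers stand for an effect already at smaller amounts and higher numbers for an effect only at larger amounts of compound. Compound 2 `Cc1cc(C)c2ccc(=O)n(CCN3CCCCC3)c2n1` gives 3.05 ug/mL in this assay, a 6.9-fold lower number from compound 1 to compound 2 (0.84 log units; beyond the scatter), so compound 2 stands lowest of the two measured compounds. Compound 3 `Cc1cc(C)c2ccc(=O)n(CC(C)(C)N(C)C)c2n1` differs from compound 2 by 1-(dimethylamino)-1-methylethyl in place of (piperidin-1-yl)methyl on a saturated chain carbon bound to an aromatic nitrogen. Going by the values given here, the only measured step that bears on this change, the one from compound 1 to compound 2, also altered the amine on the chain and was modest in size. For compound 3 a smaller step in this assay is expected, a 1.6-fold higher number from compound 2 to compound 3 (0.21 log units; within the scatter). Compound 3 is therefore estimated to give about 5 ug/mL, within 1.5 ug/mL to 15 ug/mL.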

Compound 3, half-maximal effective concentration: 10.4 ug/mL
The estimate for compound 3 lay 2.1-fold (0.32 log units) below the measured number; low and high end bracket the measured number.
By their numbers in this assay, from the lowest: compound 2; then compound 3; then compound 1.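

In this assay this assay, exchanging (piperidin-1-yl)methyl for 1-(dimethylamino)-1-methylethyl on this saturated chain carbon raises the number beyond the scatter (as a 3.4-fold higher number from compound 2 to compound 3 (0.53 log units; beyond the scatter)), so this position responds to a change that the earlier step did not test. The same group still lies on the lower side of the (methylamino)methyl group (as a 2.0-fold lower number from compound 1 to compound 3 (0.31 log units; beyond the scatter)), which places compound 3 between the other two. Nothing available explains this order.

Compound 3 alters both the amine and the chain carbon, and the two changes cannot be separated here. From the compounds shown here alone, whether a pyrrolidine, a morpholine or a longer chain would lower the number remains open.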